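A few compounds are considered here, and "the series" means these few. Any claim that something is new, unique, unknown or untested is made for them only; others in the source may bear on it.

Of the compounds shown here, three that share one core have been tested in a functional assay on HeLa cells (Homo sapiens) for inhibition, read by MTT assay, with a stated time of 48 h; a higher number here means a weaker inhibitor, a lower number a stronger inhibitor. Compound 1 `CCOC(=O)C1=C(N/C=N/c2cccnc2Cl)Nc2[nH]nc(C)c2C1c1ccc(N(C)C)cc1` gives 4630 nM, the lowest of the three numbers, so it is the strongest inhibitor among them. Compound 2 `CCOC(=O)C1=C(N/N=C(/Cl)c2ccc([N+](=O)[O-])cc2)Nc2[nH]nc(C)c2C1c1ccc(N(C)C)cc1` gives 46200 nM in this assay, and compound 3 `CCOC(=O)C1=C(N/C=N/c2ccc(C)cc2)Nc2[nH]nc(C)c2C1c1ccc(N(C)C)cc1` gives 43200 nM. Both steps away from compound 1 run the same way: a 10-fold higher number from compound 1 to compound 2 (1.00 log units; beyond the scatter), and a 9.3-fold higher number from compound 1 to compound 3 (0.97 log units; beyond the scatter). Compound 2 and compound 3 sit within the usual scatter of each other: a 1.1-fold lower number from compound 2 to compound 3 (0.03 log units; within the scatter).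

Compound 4 `CCOC(=O)C1=C(N)Nc2[nH]nc(C)c2C1c1ccc(N(C)C)cc1` has not yet been measured. It differs from compound 1 in one place: a hydrogen atom in place of a group of 9 heavy atoms (6 carbon, 2 nitrogen, 1 chlorine; one six-membered aromatic ring with 1 hetero atom), on an amine nitrogen. Among the measured compounds shown here, only a hydrogen atom is left on that amine nitrogen, so this is a removal rather than an exchange, and no measured step shows a removal. The nearest guides are the two exchanges at this same position, a 10-fold higher number from compound 1 to compound 2 (1.00 log units; beyond the scatter) and a 9.3-fold higher number from compound 1 to compound 3 (0.97 log units; beyond the scatter), each of which replaced the 2-chloropyridin-3-yl group and gave a clearly higher number. A step of about that size, again towards a higher number, is therefore expected: an 8.6-fold higher number from compound 1 to compound 4 (0.94 log units; beyond the scatter). Compound 4 is expected to give about 40000 nM in this assay, with a likely range from 10000 nM to 150000 nM.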

Compound 4, half-maximal inhibitory concentration: 6220 nM
The estimate for compound 4 lay 6.4-fold (0.81 log units) above the measured number; measured number below the stated range.
By their numbers in this assay, from the lowest: compounds 1 and 4 (each within the scatter of the next); then compounds 3 and 2 (each within the scatter of the next).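

With only a hydrogen atom on the amine nitrogen, whose other neighbour is the double-bonded ring carbon, the number in this assay stays level with that of the compound carrying the large 2-chloropyridin-3-yl-bearing group: a 1.3-fold higher number from compound 1 to compound 4 (0.13 log units; within the scatter). The large group of compound 1 is therefore not required for this level of inhibition, and the weaker numbers of the two other compounds go with the groups they carry, not with the loss of the group found in compound 1, as a 6.9-fold lower number from compound 3 to compound 4 (0.84 log units; beyond the scatter) and a 7.4-fold lower number from compound 2 to compound 4 (0.87 log units; beyond the scatter) show. Nothing measured here explains why the bare amine and compound 1 stand level, or why the two other groups give higher numbers.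

As far as these compounds go, it remains open whether a small group on this nitrogen, such as methyl or acetyl, would stay level with compound 4 or move towards compound 2 and compound 3. The compounds shown also cannot separate the part played by the ring nitrogen from that of the chlorine in compound 1, which a pyridin-3-yl group without chlorine or a chlorine-bearing phenyl group could address.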